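From dimethylamino to (oxetan-3-yl)amino on the chain

The source may hold more compounds than are shown below. What is called first, only, known or untested is meant among the compounds shown, and "the series" means these compounds.

- compound 1 `NC(=O)NCCCCN(C[C@H]1Cc2ncccc2CN1)[C@H]1CCCc2cccnc21` gives 32%
- compound 2 `NC(=O)NC/C=C\CN(C[C@H]1Cc2ncccc2CN1)[C@H]1CCCc2cccnc21` gives 10%
- compound 3 `CN(C)CCCCN(C[C@H]1Cc2ncccc2CN1)[C@H]1CCCc2cccnc21` gives 55%

These numbers come from an ADME assay on microsomes from liver (Mus musculus) for metabolic stability, using NADPH, with a stated time of 10 min; on this read-out lower numbers stand for a less stable compound and higher numbers for a more stable compound. Of the three, compound 3 stands highest at 55%, and its gaps to both others lie beyond the scatter.

The next compound to be tested is compound 4 `c1cnc2c(c1)CN[C@@H](CN(CCCCNC1COC1)[C@H]1CCCc3cccnc31)C2`. It keeps the shared core and the chain of compound 3, but the end group changes: (oxetan-3-yl)amino in place of dimethylamino on a saturated chain carbon, four bonds along the chain from an amine nitrogen. For the measured compounds named here, the closest guide is the one measured swap of an end group on this same chain: a number 23 percentage points higher from compound 1 to compound 3 (beyond the scatter), where dimethylamino replaces ureido. Like ureido, the entering (oxetan-3-yl)amino carries oxygen, which dimethylamino lacks, so the move away from dimethylamino may give back part of that gain. Going by the values given here, this is only a single comparison, and the two groups are far from identical.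

The other two steps say less. a number 22 percentage points lower from compound 1 to compound 2 (beyond the scatter) alters the chain rather than its end group, and a number 45 percentage points higher from compound 2 to compound 3 (beyond the scatter) alters both, whereas compound 4 keeps the chain unchanged.

The expected result is a modest fall, a number 15 percentage points lower from compound 3 to compound 4 (beyond the scatter). The estimate for compound 4 is 40%, with an expected range from 20% to 60%.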

Compound 4, percent of the compound remaining: 41%
The estimate for compound 4 lay 1 percentage points below the measured number, within the range that was stated.
By their numbers in this assay, from the lowest: compound 2; then compounds 1 and 4 (each within the scatter of the next); then compound 3.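

On a saturated chain carbon, four bonds along the chain from an amine nitrogen, this assay now has a second end group that falls short of dimethylamino: a number 14 percentage points lower from compound 3 to compound 4 (beyond the scatter), and this time the entering group is (oxetan-3-yl)amino, with a four-membered ring that ureido lacks. The step of a number 9 percentage points higher from compound 1 to compound 4 (within the scatter) places the ring-bearing group and ureido on the same level on this chain, whereas a number 31 percentage points higher from compound 2 to compound 4 (beyond the scatter) spans a change in both the chain and its end group, so it cannot be assigned to either one alone. No measurement shown gives a reason for these differences.

On these data alone, what stays open is whether the oxygen, the ring or the hydrogen on the amine nitrogen matters most, and cyclobutylamino, which has the same four-membered ring with carbon in place of oxygen, would separate the first two. The chain of compound 2 with dimethylamino at its end, or the chain of compound 3 with a morpholine at its end, would also show whether the ranking of end groups holds beyond this one chain and these three groups.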